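A few compounds are considered here, and "the series" means these few. Any claim that something is new, unique, unknown or untested is made for them only; others in the source may bear on it.

In a functional assay on MCF7 cells (Homo sapiens) for inhibition, read by trypan blue exclusion, with a stated time of 3 days (on this read-out lower numbers stand for stronger inhibition and higher numbers for weaker inhibition), compound 1 (`COc1cc(C(=O)c2cn(-c3ccccc3)cc2-c2ccccc2F)cc(OC)c1OC`) gives 30 nM and shares the low end of the three numbers with compound 2 (`COc1cc(C(=O)c2cn(-c3ccccc3)cc2-c2cccc(F)c2)cc(OC)c1OC`) at 57 nM, while compound 3 (`COc1cc(C(=O)c2cn(-c3ccccc3)cc2-c2ccc(C)cc2)cc(OC)c1OC`) gives 280 nM and stands apart. Compound 4 (`COc1cc(C(=O)c2cn(-c3ccccc3)cc2-c2ccc(F)cc2)cc(OC)c1OC`) differs from compound 1 in one place (4-fluorophenyl in place of 2-fluorophenyl on an aromatic carbon): 4-fluorophenyl in place of 2-fluorophenyl on an aromatic carbon. Among the compounds with values here, no measured compound carries this group. The 3-fluorophenyl of compound 2 gave only a small step (a 1.9-fold higher number from compound 1 to compound 2 (0.28 log units; within the scatter)), and the 4-methylphenyl of compound 3 gave a larger one (a 9.3-fold higher number from compound 1 to compound 3 (0.97 log units; beyond the scatter)). A rise of intermediate size, toward weaker inhibition, is therefore expected in this assay for the new compound. The estimated change is a 3.3-fold higher number from compound 1 to compound 4 (0.52 log units; beyond the scatter) in this forecast. For compound 4 the expected value is 100 nM, with an estimated range from 40 nM to 250 nM as the likely span.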

Compound 4, half-maximal inhibitory concentration: 78 nM
Beside the measured number, compound 4's estimate is 1.3-fold (0.11 log units) above it; low and high end bracket the measured number.
By their numbers in this assay, from the lowest: compounds 1, 2 and 4 (each within the scatter of the next, the first and the last beyond it); then compound 3.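

In this assay, moving the fluorine around the phenyl ring has a modest effect: the 4-fluorophenyl gives a 2.6-fold higher number from compound 1 to compound 4 (0.41 log units; beyond the scatter), while a 1.4-fold higher number from compound 2 to compound 4 (0.14 log units; within the scatter) leaves the 3-fluorophenyl and 4-fluorophenyl indistinguishable. The group on the ring also counts, since fluoro in place of methyl gives a 3.6-fold lower number from compound 3 to compound 4 (0.56 log units; beyond the scatter). Nothing available explains these differences. As far as these compounds go, whether a 4-aminophenyl or a phenyl ring bearing a carboxylic acid would keep these low numbers remains open.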